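A few compounds are considered here, and "the series" means these few. Any claim that something is new, unique, unknown or untested is made for them only; others in the source may bear on it.

Compound 3, whose structure is `CC(=O)c1ccc(NC(=O)C(CC(C)C)N(C(=O)c2ccccc2)S(=O)(=O)c2ccccc2)cc1`, sits in the middle of three compounds measured in a functional assay for inhibition, read by spectrophotometry, with a stated time of 20 min, tested at 2 mg/mL; a higher number here means a stronger effect of the compound at the concentration tested, a lower number a weaker effect. In this assay compound 3 gives 33.7%. Its nearest neighbour is compound 2, with the structure `CC(=O)c1ccc(NC(=O)CN(C(=O)c2ccccc2)S(=O)(=O)c2ccccc2)cc1`; in this assay compound 2 gives 40.5%. The furthest is compound 1, with the structure `CCC(C)C(C(=O)Nc1ccc(C(C)=O)cc1)N(C(=O)c1ccccc1)S(=O)(=O)c1ccc(C)cc1`; in this assay compound 1 gives 25.7%. All three values lie close together.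

Compound 4 has the structure `CCC(C)C(C(=O)Nc1ccc(C(C)=O)cc1)N(C(=O)c1ccccc1)S(=O)(=O)c1ccccc1`. It differs from compound 3 in one spot: sec-butyl in place of isobutyl on a saturated chain carbon bound to an amide-type nitrogen and a carbonyl carbon

Among the compounds with values here, only one measured step bears on this position. The step of a number 6.8 percentage points lower from compound 2 to compound 3 (within the scatter) shows that putting a four-carbon branched group onto that chain carbon hardly moved the number. Compound 1 also carries a sec-butyl group here, yet it differs from compound 4 in a second place as well, so it only gives a rough orientation. Swapping one four-carbon branched group for another is therefore expected to give a step of a number 3.7 percentage points lower from compound 3 to compound 4 (within the scatter), within the scatter. Compound 4 is estimated at 30%, expected between 18% and 42%.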

Compound 4, a percentage reported as inhibition, at one concentration (the size of the read-out at that concentration, not a potency): 11.4%
The estimate for compound 4 lay 18.6 percentage points above the measured number, outside the stated range (below it).
By their numbers in this assay, from the lowest: compound 4; then compounds 1, 3 and 2 (each within the scatter of the next, the first and the last beyond it).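

In this assay, sec-butyl in place of isobutyl gives a number 22.3 percentage points lower from compound 3 to compound 4 (beyond the scatter), so at this saturated chain carbon the arrangement of the four carbons matters, not only their number. Sec-butyl in place of hydrogen gives a number 29.1 percentage points lower from compound 2 to compound 4 (beyond the scatter), a step beyond the scatter, whereas isobutyl in place of hydrogen gave a number 6.8 percentage points lower from compound 2 to compound 3 (within the scatter). Hydrogen in place of methyl on an aromatic carbon gives a number 14.3 percentage points lower from compound 1 to compound 4 (beyond the scatter), so with sec-butyl on the chain carbon, that methyl also makes a difference.

Going by these compounds, whether a longer chain, an amine or a carboxylic acid on the chain carbon would fit this picture stays open, as does whether the methyl would matter with isobutyl on that carbon. Nothing measured here gives a reason for any of these steps.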